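Chloro to Bromo Repeated on a Second Core

The source may hold more compounds than are shown below. What is called first, only, known or untested is meant among the compounds shown, and "the series" means these compounds.

Compound 1 `Clc1ccc(CSc2nnc(-c3cnccn3)o2)cc1`: 24600 nM
Compound 2 `Brc1ccc(CSc2nnc(-c3cnccn3)o2)cc1`: 21600 nM
Compound 3 `Clc1ccc(CSc2nnc(-c3cnccn3)s2)cc1`: 18900 nM

These three numbers come from a functional assay on HeLa cells (Homo sapiens) for antiproliferative activity, read by MTT assay, with a stated time of 48 h; a lower number here means a stronger inhibitor, a higher number a weaker inhibitor. For the measured compounds named here, the one change measured so far, (bromo in place of chloro on an aromatic carbon), gave a 1.1-fold lower number from compound 1 to compound 2 (0.06 log units; within the scatter), a step within the scatter of the method. Compound 3 carries the same chloro group as compound 1 but on a different core; the difference between the two cores is not broken down here. Compound 4 `Brc1ccc(CSc2nnc(-c3cnccn3)s2)cc1` applies the same change to compound 3: bromo in place of chloro on an aromatic carbon. The place is described in the same words for both pairs, so this is the same change. From compound 3 to compound 4 the step is expected to be a 1.1-fold lower number from compound 3 to compound 4 (0.05 log units; within the scatter), small, resting on the earlier step of a 1.1-fold lower number from compound 1 to compound 2 (0.06 log units; within the scatter). Compound 4 is therefore estimated at 17000 nM, likely between 9000 nM and 34000 nM.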

Compound 4, half-maximal inhibitory concentration: 12400 nM
Compound 4: middle estimate off by 1.4-fold (0.14 log units), on the high side, and the stated range covers the measured number.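

In this assay, putting bromo in place of chloro on the second core gives a 1.5-fold lower number from compound 3 to compound 4 (0.18 log units; within the scatter). Set beside the same change on the first core, the two steps agree as far as this method can tell: the same change on two cores in this assay, a 1.1-fold lower number (0.06 log units; within the scatter) from compound 1 to compound 2 and a 1.5-fold lower number (0.18 log units; within the scatter) from compound 3 to compound 4, 1.3-fold (0.13 log units) apart, within the scatter of two such steps

So on these two cores the change leaves the number within the scatter both times, and the two results are consistent with each other. This does not show that a change with a clear effect would carry over in the same way, as neither step here is large enough to test that.

The compounds shown hold only chloro and bromo at this place on the ring. Going by these compounds, it stays open what an amine, a carboxylic acid or a longer chain there would do on either core, and whether any such effect would match between the two.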